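A few compounds are considered here, and "the series" means these few. Any claim that something is new, unique, unknown or untested is made for them only; others in the source may bear on it.

Measured compounds:
Compound 1 `Nc1ncc(-c2cnn(C3CCNCC3)c2)cc1-c1nc2ccc(Nc3ccc(F)cc3)cc2o1`: 3700 nM in an assay on isolated protein for inhibition of G protein-coupled receptor kinase 5 (Homo sapiens), read by TR-FRET, with stated times of 10 min and 1 h; a lower number here means a stronger inhibitor, a higher number a weaker inhibitor
Compound 2 `Nc1ncc(-c2cnn(C3CCNCC3)c2)cc1-c1nc2ccc(-c3cn[nH]c3)cc2o1`: 1780 nM in this assay

Compound 2 gives the lowest of the two numbers in this assay; its nearest neighbour is compound 1, and the step of a 2.1-fold lower number from compound 1 to compound 2 (0.32 log units; beyond the scatter) lies beyond the scatter. Compound 3 `Nc1ncc(-c2cnn(C3CCNCC3)c2)cc1-c1nc2ccc(OCc3ccccc3)cc2o1` has not been measured. It differs from compound 2 by benzyloxy in place of 1H-pyrazol-4-yl on an aromatic carbon. Among the compounds with values here, the only measured step that touches this place is a 2.1-fold lower number from compound 1 to compound 2 (0.32 log units; beyond the scatter), which shows the pyrazolyl of compound 2 giving a lower number than a substituent holding a six-membered aromatic ring of carbon only. Compound 3 again carries such a substituent, now as benzyloxy, so a modest step back toward a higher number is expected, of about a 2.0-fold higher number from compound 2 to compound 3 (0.29 log units; within the scatter). Within the data shown here, the estimate for compound 3 in this assay is 3500 nM, with a range from 1200 nM to 10000 nM, resting on the single step from compound 1 to compound 2 and therefore uncertain.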

Compound 3, half-maximal inhibitory concentration: 6900 nM
Beside the measured number, compound 3's estimate is 2.0-fold (0.29 log units) below it, and the stated range covers the measured number.
By their numbers in this assay, from the lowest: compound 2; then compounds 1 and 3 (each within the scatter of the next).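

In this assay, benzyloxy in place of 1H-pyrazol-4-yl gives a 3.9-fold higher number from compound 2 to compound 3 (0.59 log units; beyond the scatter), so at this position the pyrazolyl of compound 2 now stands apart from two different substituents that each hold a six-membered aromatic ring of carbon only. Those two substituents are not told apart here: benzyloxy in place of (4-fluorophenyl)amino gives a 1.9-fold higher number from compound 1 to compound 3 (0.27 log units; within the scatter), which lies within the scatter. Nothing measured here accounts for these differences.

The compounds shown leave open whether other five-membered aromatic rings, such as an imidazole or a thiazole, would match the pyrazolyl at this position. They also leave open how a methyl-substituted pyrazole, or a group without a ring, such as an amine or a carboxylic acid, would compare with compound 2.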